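This account rests on a few compounds, and the source may have more. Where it says the series, first, only, none or still open, it means among the compounds named here.

Two compounds share one core and differ only in the group attached to an amine nitrogen in a ring. Compound 1, `N#Cc1ccc(Nc2nc(Oc3ccnc4ccccc34)nc(N3CCN(c4ccccc4Cl)CC3)n2)cc1C(F)(F)F`, carries a 2-chlorophenyl there, and in a functional assay on DU-145 cells (Homo sapiens) for cytotoxicity, read by sulforhodamine B assay, with a stated time of 48 h (on this read-out lower numbers stand for stronger inhibition of growth and higher numbers for weaker inhibition of growth), compound 1 gives 92600 nM. Compound 2, `N#Cc1ccc(Nc2nc(Oc3ccnc4ccccc34)nc(N3CCN(c4ccc(F)cc4)CC3)n2)cc1C(F)(F)F`, carries a 4-fluorophenyl instead. In this assay compound 2 reaches only a limit, > 100000 nM, which is the edge of what the assay reports rather than a number. The step of an at least 1.0-fold higher number from compound 1 to compound 2 (0.03 log units; that floor lies within the scatter) can therefore not be sized beyond (the limit of > 100000 nM in this assay, at which 1 of the 2 values shown sits), and it stays within the usual scatter. Compound 3, `CC(=O)N1CCN(c2nc(Nc3ccc(C#N)c(C(F)(F)F)c3)nc(Oc3ccnc4ccccc34)n2)CC1`, makes a different kind of change: acetyl in place of 4-fluorophenyl on an amine nitrogen in a ring. Among the measured compounds shown here, no measured step swaps an aromatic ring for an acetyl, so the one aryl-to-aryl step that stayed within scatter is the only guide. Compound 3 is thus expected to show no step beyond the scatter, a number no higher from compound 2 to compound 3 (the limit leaves the size open), with an estimate of 100000 nM in this assay, ranging from 30000 nM to 300000 nM.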

Compound 3, concentration for 50% growth inhibition: 75100 nM
For compound 3 the middle estimate is 1.3-fold (0.12 log units) above the measured one; the range from low to high includes it.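

The earlier step only swapped one aromatic ring for another, whereas this change removes the ring from the amine nitrogen altogether, and against 2-chlorophenyl the result is a 1.2-fold lower number from compound 1 to compound 3 (0.09 log units; within the scatter). Against 4-fluorophenyl the result is an at least 1.3-fold lower number from compound 2 to compound 3 (0.12 log units; that floor lies within the scatter), and that step can be sized no further than its floor: the limit of > 100000 nM in this assay, at which 1 of the 3 values shown sits. In this assay, the steps that can be read therefore do not separate an aromatic ring from an acetyl at this position, and all the numbers shown stand for weak inhibition of growth.

Going by these compounds, the effect of an amine on a short chain, or of a carboxylic acid on a longer chain, at this nitrogen remains open. Also open, on these data alone, is whether any group here can produce a step beyond the scatter, or whether a change elsewhere on the shared core would be needed.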